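The compounds below may be only part of what the source reports. "The series", "measured", "known", "first", "only" and "open" are said of these compounds alone.

In a functional assay on A549 cells (Homo sapiens) for inhibition, read by colorimetric assay and MTT assay, with a stated time of 72 h (a lower number here means a stronger inhibitor, a higher number a weaker inhibitor), compound 1 `C=CCCCCOc1cc(F)ccc1-c1cnc(OCCC=C)n1C` gives 74000 nM and compound 2 `CCCCOc1ncc(-c2ccccc2OC)n1C` gives 87000 nM, so the two stand level within the usual scatter. Compound 3 `CCCCCCOc1ncc(-c2ccccc2OC)n1C` differs from compound 2 by ethyl in place of hydrogen on a saturated chain carbon, four bonds along the chain from an oxygen on an aromatic ring, with ethyl in place of hydrogen on a saturated chain carbon. Within the data shown here, no measured step shows what such a change does, so only a small shift toward a lower number is expected in this assay, close to the scatter. The expected step is a 1.5-fold lower number from compound 2 to compound 3 (0.16 log units; within the scatter). For compound 3 the estimated value is 60000 nM, within an expected range of 25000 nM to 120000 nM.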

Compound 3, half-maximal inhibitory concentration: 37000 nM
For compound 3 the middle estimate is 1.6-fold (0.21 log units) above the measured one, within the range that was stated.
By their numbers in this assay, from the lowest: compounds 3, 1 and 2 (each within the scatter of the next, the first and the last beyond it).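

Ethyl in place of hydrogen on a saturated chain carbon, four bonds along the chain from an oxygen on an aromatic ring, gives a 2.4-fold lower number from compound 2 to compound 3 (0.37 log units; beyond the scatter) in this assay. This is a first sign that the number responds to a change at this position, which compounds 1 and 2, differing in more than one place, could not show. The data shown offer no measured explanation for this step. As far as these compounds go, whether a longer chain would extend the step remains open, as does the effect of an amine or a carboxylic acid at this position.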